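A few compounds are considered here, and "the series" means these few. Any claim that something is new, unique, unknown or untested is made for them only; others in the source may bear on it.

Compound 1 `N=S1(=O)c2ccccc2C(=O)N1c1ccccc1` gives 578000 nM
Compound 2 `NC1=NS(=O)(=O)c2ccccc21` gives 798000 nM
Compound 3 `CCN=S1(=O)NC(=O)c2ccccc21` gives 947000 nM

In a physicochemical assay for solubility (on this read-out lower numbers stand for lower solubility and higher numbers for higher solubility), the three measured compounds lie close together. Compound 2 holds the second highest of the three numbers: its nearest neighbour is compound 3, whose number is within the scatter of it, and the furthest is compound 1, whose number is also within the scatter. No pair of these compounds differs in a single place, so no measured step is available to guide the next one.

Compound 4 `O=S1(=O)N=C(Nc2ccccc2)c2ccccc21` is compound 2 with phenyl in place of hydrogen on an amine nitrogen. Nothing measured here shows what this change does to the read-out. Among the compounds with values here, the only hint is that compound 1, which also carries a phenyl, gives 578000 nM, a number within the scatter of compound 2. A downward step, somewhat beyond the scatter, is nevertheless expected for compound 4 in this assay, of the size a 4.0-fold lower number from compound 2 to compound 4 (0.60 log units; beyond the scatter). Compound 4 is therefore estimated at 200000 nM, with a range from 60000 nM to 600000 nM.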

Compound 4, solubility: 7000 nM
Compound 4: middle estimate off by 29-fold (1.46 log units), on the high side; the measured number lies below the stated range.
By their numbers in this assay, from the lowest: compound 4; then compounds 1, 2 and 3 (each within the scatter of the next).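

In this assay, the amine nitrogen of compound 2 proves to be a place where a single change moves the number a long way: phenyl in place of hydrogen gives a 110-fold lower number from compound 2 to compound 4 (2.06 log units; beyond the scatter). Within the data shown here, this is the first step available, and it is large, whereas the three earlier compounds lay within the scatter of one another and could not show what any one change does. Nothing given here bears on why a phenyl at this nitrogen has an effect of this size.

As far as these compounds go, it remains open whether methyl or a longer alkyl chain on the same amine nitrogen would give a step of similar size, or whether the size depends on the aromatic ring itself. From the compounds shown here alone, it is also open whether an amine or a carboxylic acid on the phenyl would bring the number back towards that of compound 2.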